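Chain lengthening on the shared core: compound 3 expected

The source may report more compounds than this note shows. Statements on the series, on what has been measured and on what is new or still open speak of the compounds shown alone.

Measured so far:
compound 1, `Cc1nc(N2CCC2)nc(OC2CCC2)c1O`: 100%
compound 2, `CCCCCCCCCCCCCCc1nc(N2CCC2)nc(OC2CCC2)c1O`: 105%

In a functional assay on cells (Lymphocyte, Homo sapiens), read by a luciferase reporter and ATP content, with a stated time of 48 h, tested at 1 uM (on this read-out higher numbers stand for a weaker effect at the one concentration tested and lower numbers for a stronger effect), compound 1 gives 100%, and compound 2 gives 105%. Compound 2 stands highest of the two numbers, with compound 1 nearest, a number a little lower but within the scatter, so no order between the two can be read. Both numbers sit at the level of no effect at the single concentration used in this assay.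

Compound 3, `CCCCCCCCCCCCCCCCc1nc(N2CCC2)nc(OC2CCC2)c1O`, has not been measured. It differs from compound 2 by ethyl in place of hydrogen on a saturated chain carbon, ten or more bonds along the chain from an aromatic carbon. Among the compounds with values here, no step between measured compounds is known, and the two numbers in hand do not separate. Within the data shown here, the change is small and sits far along the chain, and the series so far shows no effect anywhere, so no step beyond the scatter is expected in this assay. Because compound 2 gives 105%, compound 3 is expected to stay at the same level. The expected change is a number 3 percentage points lower from compound 2 to compound 3 (within the scatter), within the scatter. Compound 3 is estimated at 102%, with a range from 88% to 116%.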

Compound 3, a percentage reported as activity, at one concentration (the size of the read-out at that concentration, not a potency): 100%
Estimate against measurement, compound 3: 2 percentage points above, within the range that was stated.
By their numbers in this assay, from the lowest: compounds 1, 3 and 2 (each within the scatter of the next).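

In this assay, within the data shown here, ethyl in place of hydrogen on a saturated chain carbon, ten or more bonds along the chain from an aromatic carbon, gives a number 5 percentage points lower from compound 2 to compound 3 (within the scatter), the only step that can be read so far. Among these compounds, at this place, then, the added ethyl leaves the read-out at the one concentration tested inside the usual scatter, with compound 3 at 100%, and the single step gives no sign that this change matters in this assay. No measurement on these compounds bears on the reason for this result.

The compounds shown leave open whether an amine or a carboxylic acid carried on the chain, rather than the plain saturated chain of compound 2 and compound 3, would give a step beyond the scatter in this assay. They also leave open what a readout at other concentrations would show for this chain, and whether a ring such as phenyl in place of ethyl at this place would behave as ethyl does.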